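Methoxy addition on the thioether and sulfoxide aryl ring

The source may hold more compounds than are shown below. What is called first, only, known or untested is meant among the compounds shown, and "the series" means these compounds.

Measured compounds:
Compound 1 `N#Cc1c(N)cccc1Sc1ccccc1`: 168000 nM
Compound 2 `COc1cccc(Sc2cccc(N)c2C#N)c1`: a limit of the assay, > 200000 nM
Compound 3 `N#Cc1c(N)cccc1[S+]([O-])c1cccc(C(F)(F)F)c1`: 125000 nM

In a functional assay on MT4 cells (Homo sapiens) for cytotoxicity (a higher number here means a weaker inhibitor, a lower number a stronger inhibitor), compound 1 gives 168000 nM. Compound 2 reaches only the assay limit of > 200000 nM. Compound 3 gives 125000 nM, which sits within the usual scatter of compound 1. Among the compounds with values here, the one counted step, (methoxy in place of hydrogen on an aromatic carbon), gives an at least 1.1-fold higher number from compound 1 to compound 2 (0.07 log units; that floor lies within the scatter); its size has a floor set by the limit of > 200000 nM in this assay, at which 1 of the 3 values shown sits. How the cores of compound 1 and compound 3 differ is not broken down here.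

Compound 4 `COc1cc([S+]([O-])c2cccc(N)c2C#N)cc(C(F)(F)F)c1` is not yet measured. It carries the same kind of change as compound 2, (methoxy in place of hydrogen on an aromatic carbon); the place differs in that here it is also meta to a trifluoromethyl group. Resting on an at least 1.1-fold higher number from compound 1 to compound 2 (0.07 log units; that floor lies within the scatter), a small step is expected, a 1.2-fold higher number from compound 3 to compound 4 (0.08 log units; within the scatter). Compound 4 is estimated at 150000 nM, between 80000 nM and 200000 nM.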

Compound 4, half-maximal inhibitory concentration: 108000 nM
Beside the measured number, compound 4's estimate is 1.4-fold (0.14 log units) above it; measured number inside the range.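

In this assay, methoxy in place of hydrogen on an aromatic carbon gives a 1.2-fold lower number from compound 3 to compound 4 (0.06 log units; within the scatter), so no step beyond the scatter is seen on the core of compound 3. Set against the core of compound 1, the comparison stands as follows: the same change on two cores in this assay, an at least 1.1-fold higher number (0.07 log units; that floor lies within the scatter) from compound 1 to compound 2 and a 1.2-fold lower number (0.06 log units; within the scatter) from compound 3 to compound 4; the limit leaves it open whether they differ. This does not show that the change carries over from one core to the other unaltered, as the earlier step has only a floor: the limit of > 200000 nM in this assay, at which 1 of the 4 values shown sits.

The compounds shown leave open what an amine, a carboxylic acid or a longer alkoxy chain would give in place of methoxy. From the compounds shown here alone, how the nitrile on the shared core bears on this assay also stays open.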